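The source may hold more compounds than are shown below. What is called first, only, known or untested is meant among the compounds shown, and "the series" means these compounds.

Measured in a functional assay on RS4-11 cells (Homo sapiens) for inhibition, read by CCK-8 assay, with a stated time of 48 h, tested at 20 uM; on this read-out lower numbers stand for less inhibition of growth and higher numbers for more inhibition of growth at the one concentration tested:
- Compound 1 `N#C/C(=C\c1ccccc1OS(=O)(=O)c1ccc([N+](=O)[O-])cc1)C(=O)Nc1nnc(-c2cccs2)s1`: 40%
- Compound 2 `COc1ccc(Cc2nnc(NC(=O)/C(C#N)=C/c3ccccc3OS(=O)(=O)c3ccc(OC)cc3)s2)cc1`: 78%

Compound 2 holds the higher of the two numbers at 78%, and the gap down to compound 1 lies beyond the scatter. Compound 3 `COc1ccc(Cc2nnc(NC(=O)/C(C#N)=C/c3ccccc3OS(=O)(=O)c3ccc([N+](=O)[O-])cc3)s2)cc1` has nitro in place of methoxy on an aromatic carbon, para to a large group, compared with compound 2 (nitro in place of methoxy on an aromatic carbon). Within the data shown here, no measured pair isolates this change. Compound 1 also carries (4-nitrophenyl)sulfonyl and gives 40%, so a moderate fall is expected in this assay, with the estimated step of a number 16 percentage points lower from compound 2 to compound 3 (beyond the scatter). For compound 3 the expected value is 62%, with an estimated range of 38% to 85%.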

Compound 3, percent growth inhibition at one concentration: 70%
The estimate for compound 3 lay 8 percentage points below the measured number, and the stated range covers the measured number.
By their numbers in this assay, from the lowest: compound 1; then compounds 3 and 2 (each within the scatter of the next).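

In this assay, nitro in place of methoxy on the aromatic carbon para to a large group gives a number 8 percentage points lower from compound 2 to compound 3 (within the scatter), so this position tolerates the swap with no clear change in growth inhibition. With (4-nitrophenyl)sulfonyl held constant, 4-methoxybenzyl in place of thiophen-2-yl gives a number 30 percentage points higher from compound 1 to compound 3 (beyond the scatter), so the clear difference comes from that other place. Nothing available explains either step.

As far as these compounds go, whether an amine or a carboxylic acid at the same position would fit equally well remains open. So does whether the benzyl step would hold with (4-methoxyphenyl)sulfonyl.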